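The source may report more compounds than this note shows. Statements on the series, on what has been measured and on what is new or still open speak of the compounds shown alone.

Measured so far in a functional assay on T47D cells (Homo sapiens) for inhibition, read by sulforhodamine B assay, with a stated time of 48 h, tested at 100 uM; on this read-out higher numbers stand for a weaker effect at the one concentration tested and lower numbers for a stronger effect:
compound 1 `O=C(Nc1cccc(-n2cc(-c3ccncc3)c(-c3cc(O)cc(Cl)c3)n2)c1)Nc1ccc(Cl)c(Cl)c1` gives -39%
compound 2 `COc1cc(Cl)cc(-c2nn(-c3cccc(NC(=O)Nc4cc(C(F)(F)F)cc(C(F)(F)F)c4)c3)cc2-c2ccncc2)c1` gives -22%
compound 3 `COc1cc(Cl)cc(-c2nn(-c3cccc(NC(=O)Nc4ccc(Cl)c(Cl)c4)c3)cc2-c2ccncc2)c1` gives -9%

Among the compounds with values here, compound 3 stands highest of the three numbers in this assay; the nearest is compound 2, beyond the scatter below it, and the furthest is compound 1, reached by the single change a number 30 percentage points higher from compound 1 to compound 3 (beyond the scatter).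

Compound 4 `COc1cc(Cl)cc(-c2nn(-c3cccc(NC(=O)c4cccc(C(F)(F)F)c4)c3)cc2-c2ccncc2)c1` differs from compound 3 in one place: 3-(trifluoromethyl)phenyl in place of (3,4-dichlorophenyl)amino on a carbonyl carbon. Within the data shown here, no measured step covers this change; the only step in hand, a number 30 percentage points higher from compound 1 to compound 3 (beyond the scatter), concerns the methyl on an oxygen and lies elsewhere in the molecule. Compounds 2 and 3 differ at the same far end of the molecule while keeping the amide-type nitrogen, and their values sit beyond the scatter apart, so this region does move the read-out, but in which direction the present change will move it cannot be read from the data. The step of a number 1 percentage points higher from compound 3 to compound 4 (within the scatter) is therefore expected to be small with an uncertain sign. For compound 4 the estimate in this assay is -8%, within a range from -35% to 20%.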

Compound 4, a percentage reported as activity, at one concentration (the size of the read-out at that concentration, not a potency): 15%
Compound 4: the middle estimate sits 23 percentage points below what was measured; measured number inside the range.
By their numbers in this assay, from the lowest: compound 1; then compound 2; then compound 3; then compound 4.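

In this assay, putting 3-(trifluoromethyl)phenyl in place of (3,4-dichlorophenyl)amino on the carbonyl carbon gives a number 24 percentage points higher from compound 3 to compound 4 (beyond the scatter) and so weakens the effect at the one concentration tested. This shows that the far end of the molecule can shift the read-out even with the rest of compound 3 unchanged, and that this particular swap moves it upward. Nothing in the data explains why the number rises.

The swap changes two things at once, removing the amino nitrogen with its hydrogen-bond donor and replacing the ring's substituents, so the compounds shown cannot separate these two parts of the step. A (3-(trifluoromethyl)phenyl)amino group or a 3,4-dichlorophenyl group on the same carbonyl carbon would be needed to tell them apart.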